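Cytotoxicity limits and the methyl step from compound 3

This account rests on a few compounds, and the source may have more. Where it says the series, first, only, none or still open, it means among the compounds named here.

In an ADME assay on MT4 cells (Homo sapiens) for cytotoxicity, read by MTT assay (on this read-out lower numbers stand for higher toxicity in this test and higher numbers for lower toxicity in this test), compound 3 (`CC(C)Sc1nc(Cc2c(F)cccc2F)cc(=O)[nH]1`) gives > 84000 nM, a limit of the assay and not a number. Compound 1 (`Cc1c(Cc2c(F)cccc2F)nc(SCc2ccccn2)[nH]c1=O`) gives > 70000 nM, also a limit. Compound 2 (`Cc1c(Cc2c(F)cccc2F)nc(SCc2ccncc2)[nH]c1=O`) gives > 70000 nM, again a limit. Every value in hand is therefore a limit, and compound 3 has no numerical position in the series.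

Compound 4 (`Cc1c(Cc2c(F)cccc2F)nc(SC(C)C)[nH]c1=O`) differs from compound 3 by one change: methyl in place of hydrogen on an aromatic carbon. Among the compounds with values here, the only measured step is a step that the two limits leave unreadable from compound 1 to compound 2, which concerns the sulfur side chain and offers no size to carry over. Within the data shown here, compounds 1 and 2 share the methyl of compound 4 but carry other groups on sulfur, so no measured pair isolates the methyl.

The expectation rests on the limits alone: no step beyond the usual scatter is expected in this assay, and another limit is the likeliest report. The expected step is an at least 1.0-fold lower number from compound 3 to compound 4 (0.02 log units; that floor lies within the scatter). For compound 4 the estimated value is 80000 nM, with an expected range from 35000 nM to 170000 nM.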

Compound 4, half-maximal cytotoxic concentration: > 77000 nM
Compound 4: only a limit was reported; the forecaster's own chance of this, stated with the estimate: 75%; the middle value is on the limit's open side.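

In this assay compound 4 gives > 77000 nM, a limit and not a number, so its steps from compound 1, compound 2 and compound 3 cannot be read. The compounds shown leave open whether methyl in place of hydrogen on an aromatic carbon changes this read-out at all.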